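The source may report more compounds than this note shows. Statements on the series, on what has been measured and on what is new or still open speak of the compounds shown alone.

Compound 1 `CC1(C)Oc2ccc(C#N)cc2[C@@H](NC(=O)Nc2ccccc2)[C@@H]1O`: 800 nM
Compound 2 `CC1(C)Oc2ccc(C#N)cc2[C@@H](/N=C(\NC#N)Sc2ccccc2)[C@@H]1O`: 4900 nM
Compound 3 `CC1(C)Oc2ccc(C#N)cc2[C@@H](NC(=O)c2ccccc2)[C@@H]1O`: 30 nM

In a functional assay (aorta) with Rattus norvegicus as the target (a higher number here means a weaker inhibitor, a lower number a stronger inhibitor), compound 2 gives 4900 nM, the highest number of the three and so the weakest inhibitor here. Both other compounds lie lower, by more than the usual scatter.

Compound 4 `CC(=O)c1cccc(N/C(=N/[C@@H]2c3cc(C#N)ccc3OC(C)(C)[C@H]2O)NC#N)c1` has not yet been measured. It differs from compound 2 in one place: (3-acetylphenyl)amino in place of phenylsulfanyl on a carbon with a double bond to nitrogen. In words, (3-acetylphenyl)amino stands in place of phenylsulfanyl on a carbon with a double bond to nitrogen.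

Going by the values given here, no measured step makes this exact change. The closest guide is a 27-fold lower number from compound 1 to compound 3 (1.43 log units; beyond the scatter), a large step in which phenyl replaces anilino on a carbonyl carbon. It shows that one group swap can move the number far, though at a different kind of carbon. Like compound 1 at 800 nM, compound 4 has a ring joined through nitrogen, so a moderate drop is expected rather than a large one. The expected change is a 3.3-fold lower number from compound 2 to compound 4 (0.51 log units; beyond the scatter), and this estimate is uncertain. For compound 4 the estimated value is 1500 nM, with an expected range of 300 nM to 6000 nM.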

Compound 4, half-maximal inhibitory concentration: 8400 nM
The estimate for compound 4 lay 5.6-fold (0.75 log units) below the measured number, outside the stated range (above it).
By their numbers in this assay, from the lowest: compound 3; then compound 1; then compounds 2 and 4 (each within the scatter of the next).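

In this assay, putting (3-acetylphenyl)amino in place of phenylsulfanyl on a carbon with a double bond to nitrogen gives a 1.7-fold higher number from compound 2 to compound 4 (0.23 log units; within the scatter) and this step lies within the usual scatter, so compound 2 and compound 4 cannot be told apart here. Going by these compounds alone, this is the first reading at this carbon, and it shows a swap with no clear effect on the number, in contrast to the large 27-fold lower number from compound 1 to compound 3 (1.43 log units; beyond the scatter) on a carbonyl carbon. No evidence is available that accounts for this result.

Going by these compounds, the swap changes the linking atom from sulfur to nitrogen and adds an acetyl group in a single step, so the effect of each part remains unknown. A plain anilino group would separate the two, and an amine or a carboxylic acid on the ring would test this position further.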